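The source may report more compounds than this note shows. Statements on the series, on what has been measured and on what is new or still open speak of the compounds shown alone.

Compound 3 `CSc1ccc(NC(=O)N[C@H]2CC[C@H](Oc3ccc(F)cc3)CC2)cc1` gives only a limit in a functional assay on CRL2813 cells (Homo sapiens) for cytotoxicity, read by sulforhodamine B assay, with a stated time of 5 days (on this read-out higher numbers stand for weaker inhibition and lower numbers for stronger inhibition), namely > 20000 nM. Compound 1 `O=C(Nc1ccc(F)cc1)N[C@H]1CC[C@H](Oc2ccc(F)cc2)CC1` gives 20000 nM in this assay, and the step of a number no lower from compound 1 to compound 3 (the limit leaves the size open). Compound 2 `O=C(Nc1ccccc1[N+](=O)[O-])N[C@H]1CC[C@H](Oc2ccc(F)cc2)CC1` gives 3500 nM, with a 5.7-fold lower number from compound 1 to compound 2 (0.76 log units; beyond the scatter) and an at least 5.7-fold higher number from compound 2 to compound 3 (0.75 log units; beyond the scatter). Compound 4 `COc1cccc(NC(=O)N[C@H]2CC[C@H](Oc3ccc(F)cc3)CC2)c1` differs from compound 3 by 3-methoxyphenyl in place of 4-(methylsulfanyl)phenyl on an amide-type nitrogen. Going by these compounds, the measured steps show that swapping the group on this nitrogen can move the number modestly, but none of them covers a 3-methoxyphenyl, so the direction stays open. For compound 4 a number near that of compound 1 is expected, with the step of an at least 1.3-fold lower number from compound 3 to compound 4 (0.12 log units; that floor lies within the scatter) from the limit of compound 3. The estimate for compound 4 in this assay is 15000 nM, ranging from 4000 nM to 40000 nM.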

Compound 4, half-maximal inhibitory concentration: 14000 nM
Estimate against measurement, compound 4: 1.1-fold (0.03 log units) above; measured number inside the range.
By their numbers in this assay, from the lowest: compound 2; then compounds 4 and 1 (each within the scatter of the next).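

In this assay, the 3-methoxyphenyl group on this amide-type nitrogen reads much like the 4-fluorophenyl group, with a 1.4-fold lower number from compound 1 to compound 4 (0.15 log units; within the scatter). It does not reach the 2-nitrophenyl group, with a 4.0-fold higher number from compound 2 to compound 4 (0.60 log units; beyond the scatter), so compound 2 still stands apart from the other three compounds. Replacing 4-(methylsulfanyl)phenyl gives an at least 1.4-fold lower number from compound 3 to compound 4 (0.15 log units; that floor lies within the scatter), a floor and not a size, set by a limit: the limit of > 20000 nM in this assay, at which 1 of the 4 values shown sits.

Going by these compounds, whether the lower number of compound 2 comes from the nitro group itself stays open. So does how an aminophenyl group or a longer alkyl chain on this nitrogen would read.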